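The source may hold more compounds than are shown below. What is called first, only, known or untested is meant among the compounds shown, and "the series" means these compounds.

Values so far in a physicochemical assay for solubility, at pH 7.4 (on this read-out higher numbers stand for higher solubility and lower numbers for lower solubility), are these:

- compound 1 (`CC[C@H]1[C@@H](N)CN1c1c(F)cc2c(=O)c(C(=O)O)cn(C3CC3)c2c1F`) gives 55.9 ug/mL
- compound 2 (`C[C@H]1[C@@H](N)CN1c1c(F)cc2c(=O)c(C(=O)O)cn(C3CC3)c2c1F`) gives 23.6 ug/mL

Compound 2 holds the lower of these two numbers. Among the compounds with values here, the one measured step, modest in size, is a 2.4-fold lower number from compound 1 to compound 2 (0.37 log units; beyond the scatter) and consists of hydrogen in place of methyl on a saturated chain carbon bound to a saturated ring carbon.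

Compound 3 (`CN[C@H]1CN(c2c(F)cc3c(=O)c(C(=O)O)cn(C4CC4)c3c2F)[C@@H]1C`) departs from compound 2 in one place (a group of 7 heavy atoms (5 carbon, 2 nitrogen; one four-membered non-aromatic ring with 1 hetero atom) in place of a group of 6 heavy atoms (4 carbon, 2 nitrogen; one four-membered non-aromatic ring with 1 hetero atom), on an aromatic carbon) and that aromatic carbon stands ortho to two fluoro groups. Within the data shown here, no measured step covers this same change, so the step above serves only as a rough guide to size. Going by a 2.4-fold lower number from compound 1 to compound 2 (0.37 log units; beyond the scatter) the shift expected in this assay is no larger than that modest one, and a slightly higher number is the likelier direction. The expected step is small (a 1.3-fold higher number from compound 2 to compound 3 (0.10 log units; within the scatter)) and is not expected to stand clear of the scatter. Compound 3 is estimated at 30 ug/mL with an expected range from 12 ug/mL to 75 ug/mL for that number.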

Compound 3, solubility: 13.1 ug/mL
The estimate for compound 3 lay 2.3-fold (0.36 log units) above the measured number, and the stated range covers the measured number.
By their numbers in this assay, from the lowest: compounds 3 and 2 (each within the scatter of the next); then compound 1.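

On the aromatic carbon ortho to two fluoro groups, this assay now covers a second kind of exchange: a group of 7 heavy atoms in place of a group of 6 heavy atoms gives a 1.8-fold lower number from compound 2 to compound 3 (0.26 log units; within the scatter), so this change does not stand clear of the scatter. Counting heavy atoms alone does not settle the number at this place, however, since the exchange between two groups of 7 heavy atoms, each with the same counts of carbon and nitrogen and the same four-membered non-aromatic ring, gives a 4.3-fold lower number from compound 1 to compound 3 (0.63 log units; beyond the scatter), a modest step that lies beyond the scatter. Nothing measured here offers an explanation for either step.

What the compounds shown leave open is how a longer chain such as propyl, or a hydroxyl group, would read on the four-membered ring in this assay. Also open, from the compounds shown here alone, is whether these steps would keep their size if an ethyl group stood in place of the cyclopropyl group on the shared core.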